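A few compounds are considered here, and "the series" means these few. Any claim that something is new, unique, unknown or untested is made for them only; others in the source may bear on it.

Measured compounds in a functional assay on CHO cells for agonist activity at Free fatty acid receptor 1 (Homo sapiens), read by calcium flux; a higher number here means that more compound is needed for the effect, a lower number that less compound is needed:
compound 1 `O=C(O)CCc1ccc(OCc2nnc(C(=O)Nc3ccccc3)s2)cc1`: 1060 nM
compound 2 `COc1ccc(NC(=O)c2nnc(COc3ccc(CCC(=O)O)cc3)s2)cc1`: > 10000 nM

In this assay compound 1 gives 1060 nM, the only number shown. Compound 2 is known only by a limit. That limit for compound 2, > 10000 nM, is a limit of the assay and not a number. The step of an at least 9.4-fold higher number from compound 1 to compound 2 (0.97 log units; beyond the scatter) is methoxy in place of hydrogen on an aromatic carbon, and one of the two values sits at the assay limit (the limit of > 10000 nM in this assay, at which 1 of the 2 values shown sits).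

Compound 3 `O=C(O)CCc1ccc(OCc2nnc(C(=O)Nc3cccc(F)c3)s2)cc1` differs from compound 1 as follows: fluoro in place of hydrogen on an aromatic carbon. Among the compounds with values here, the only measured step concerns methoxy, not fluoro, so it bears on this change only loosely. A single fluorine meta to a large group is expected to move the number little, if at all, beyond the scatter, with the methoxy step from compound 1 to compound 2 as the sole warning that substitution on this ring can cost activity. The estimated step is a 1.0-fold higher number from compound 1 to compound 3 (0.02 log units; within the scatter). Compound 3 is therefore expected to give about 1100 nM, between 400 nM and 3500 nM.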

Compound 3, half-maximal effective concentration: 1190 nM
Compound 3: middle estimate off by 1.1-fold (0.03 log units), on the low side; the measured number falls inside the stated range.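

In this assay, fluoro on the aromatic ring of the anilino group gives a 1.1-fold higher number from compound 1 to compound 3 (0.05 log units; within the scatter) and so shows that this ring can carry a substituent, here meta to a large group, with no change beyond the scatter. Substitution on this ring therefore does not cost activity in every case, as 3-fluorophenyl in place of 4-methoxyphenyl gives an at least 8.4-fold lower number from compound 2 to compound 3 (0.92 log units; beyond the scatter) and restores a measurable number. That step rests on a limit for compound 2 and not on a number: the limit of > 10000 nM in this assay, at which 1 of the 3 values shown sits.

The compounds shown leave open whether the methoxy group itself or its place on the ring sets compound 2 apart. They also leave open how this ring would respond to a trifluoromethyl group, an amine or a carboxylic acid.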